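The compounds below may be only part of what the source reports. "The series", "measured", "known", "first", "only" and "open" are said of these compounds alone.

Working notes on the series. The shared core carries a substituted sulfur chain, and in an assay for inhibition of Indoleamine 2,3-dioxygenase 1 (Homo sapiens), read by fluorescence, with a stated time of 1 h (on this read-out higher numbers stand for weaker inhibition and lower numbers for stronger inhibition), compound 3 `CSc1nonc1/C(=N/O)Nc1ccc(F)c(Br)c1` gives 560 nM, the highest number among the three measured compounds. Compound 1 `NS(=O)(=O)NCCSc1nonc1/C(=N/O)Nc1ccc(F)c(Br)c1` gives 130 nM and compound 2 `CS(=N)(=O)CC(=O)NCCSc1nonc1/C(=N/O)Nc1ccc(F)c(Br)c1` gives 61 nM in this assay.

Compound 4 `CS(=O)(=O)NCCSc1nonc1/C(=N/O)Nc1ccc(F)c(Br)c1` differs from compound 3 by (methanesulfonamido)methyl in place of hydrogen on a saturated chain carbon bound to a sulfur. Going by the values given here, the steps that bear on this are the two removals from the chain, a 4.3-fold higher number from compound 1 to compound 3 (0.63 log units; beyond the scatter) and a 9.2-fold higher number from compound 2 to compound 3 (0.96 log units; beyond the scatter); both show that a longer substituted chain on the sulfur goes with a lower number than the bare methyl of compound 3. Compound 4 is closest in kind to compound 1, since both carry a sulfonyl-bearing chain ending in a single hydrogen-bond donor. In this assay compound 4 is therefore expected to fall near compound 1, with an estimated step of a 3.7-fold lower number from compound 3 to compound 4 (0.57 log units; beyond the scatter). The estimate for compound 4 is 150 nM, with a range from 60 nM to 400 nM.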

Compound 4, half-maximal inhibitory concentration: 270 nM
The estimate for compound 4 lay 1.8-fold (0.26 log units) below the measured number; the range from low to high includes it.
By their numbers in this assay, from the lowest: compound 2; then compound 1; then compound 4; then compound 3.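

In this assay, the 2-(methanesulfonamido)ethyl chain still goes with a lower number than the bare methyl, with a 2.1-fold lower number from compound 3 to compound 4 (0.32 log units; beyond the scatter), so this change at the saturated chain carbon bound to a sulfur remains favourable, but chain extension alone does not set the number. What ends the chain also counts: methyl in place of amino on a sulfonyl sulfur gives a 2.1-fold higher number from compound 1 to compound 4 (0.32 log units; beyond the scatter), and the smaller group on the amine nitrogen gives a 4.4-fold higher number from compound 2 to compound 4 (0.65 log units; beyond the scatter). Nothing measured here gives a reason for these differences.

The compounds shown leave open how an ethyl on the sulfonyl sulfur, or a carboxylic acid at the end of the chain, would compare. Also open, from the compounds shown here alone, is whether a longer chain between the sulfur and the amine nitrogen would keep this order.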